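The source may report more compounds than this note shows. Statements on the series, on what has been measured and on what is new or still open speak of the compounds shown alone.

In a functional assay on UACC-62 cells (Homo sapiens) for inhibition, read by sulforhodamine B assay, with a stated time of 48 h (a lower number here means that less compound is tolerated, a higher number that more compound is tolerated), compound 2 `COc1cc(-c2nn(-c3cccc(NC(=O)Nc4ccc(Cl)c(C(F)(F)F)c4)c3)cc2-c2ccncc2)ccc1Cl` gives 11600 nM, the lowest of the two numbers in hand. Compound 1 `O=C(Nc1cccc(-n2cc(-c3ccncc3)c(-c3ccc(Cl)c(O)c3)n2)c1)Nc1ccc(Cl)c(Cl)c1` gives 29200 nM, a gap beyond the usual scatter. Compound 3 `O=C(Nc1cccc(-n2cc(-c3ccncc3)c(-c3ccc(Cl)c(O)c3)n2)c1)Nc1ccc(Cl)c(C(F)(F)F)c1` has not been measured; it differs from compound 2 by hydrogen in place of methyl on an oxygen on an aromatic ring. Compound 1 also carries the hydroxy group, but with a differently substituted phenyl on the urea, so no single change isolates this exchange. For compound 3 the expected step is a 1.5-fold higher number from compound 2 to compound 3 (0.17 log units; within the scatter), toward a higher number but likely within the scatter. The estimate for compound 3 is 17000 nM, ranging from 7000 nM to 40000 nM.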

Compound 3, concentration lethal to 50% of the cells: 3160 nM
Estimate against measurement, compound 3: 5.4-fold (0.73 log units) above, and the stated range ends above it.
By their numbers in this assay, from the lowest: compound 3; then compound 2; then compound 1.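

In this assay, methoxy to hydroxy on the 4-chloro-3-methoxyphenyl group gives a 3.7-fold lower number from compound 2 to compound 3 (0.56 log units; beyond the scatter), so with the rest of the molecule unchanged, this position responds to the change. With hydroxy held in place, trifluoromethyl in place of chloro on an aromatic carbon gives a 9.2-fold lower number from compound 1 to compound 3 (0.97 log units; beyond the scatter), so the substituent on the urea phenyl also matters. No measurement in hand speaks to the reason for either step.

As far as these compounds go, whether the chloro to trifluoromethyl step carries over to the methoxy compounds remains open. Also open, from the compounds shown here alone, is how an amine in place of the hydroxy, or ethoxy as a longer chain on that oxygen, would read.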